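A few compounds are considered here, and "the series" means these few. Any claim that something is new, unique, unknown or untested is made for them only; others in the source may bear on it.

In a functional assay on NALM-6 cells (Homo sapiens) for cytotoxicity, with a stated time of 72 h (on this read-out higher numbers stand for an effect only at larger amounts of compound and lower numbers for an effect already at smaller amounts), compound 1 `C=C[C@@](C)(/C=C/c1ccc(O)cc1)CCC(O)C(C)(C)O` stands at > 43400 nM which is a limit of the assay and not a number. Going by the values given here, compound 2 `C=C[C@@](C)(/C=C/c1ccc(O)c(CO)c1)CCC=C(C)C` at 16400 nM holds the only actual number so far. Compound 3 `C=C[C@@](C)(/C=C/c1ccc(O)c(/C=C/C#N)c1)CCC=C(C)C` differs from compound 2 as 2-cyanoethenyl in place of hydroxymethyl on an aromatic carbon with 2-cyanoethenyl in place of hydroxymethyl on an aromatic carbon. Among the compounds with values here, no measured step bears on this change, so the expectation in this assay is loose: a moderate fall in the value, with a 2.7-fold lower number from compound 2 to compound 3 (0.44 log units; beyond the scatter) as the estimated size. For compound 3 the estimate is 6000 nM with an expected range from 1500 nM to 24000 nM for the measurement.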

Compound 3, half-maximal effective concentration: > 43400 nM
Compound 3: no number, only a limit; the forecaster's own chance of this, stated with the estimate: 12%; at least 7.2-fold (0.85 log units) between middle value and limit.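

On the aromatic carbon ortho to a hydroxy group, the series now has its first readable single-place change: in this assay, 2-cyanoethenyl in place of hydroxymethyl gives an at least 2.6-fold higher number from compound 2 to compound 3 (0.42 log units; beyond the scatter) and so does not lower the number at this position. Compound 3 carries only a limit of the assay, so this step is a minimum and its true size stays unknown: the limit of > 43400 nM in this assay, at which 2 of the 3 values shown sit.

Open, on these data alone, is whether a methyl, an aminomethyl or a carboxylic acid on this carbon would give a lower number than compound 2. Also open, as far as these compounds go, is which part of 2-cyanoethenyl, the double bond or the nitrile, goes with the higher number.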